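Methyl in Place of Fluoro on the Aryl Ketone

The source may report more compounds than this note shows. Statements on the series, on what has been measured and on what is new or still open speak of the compounds shown alone.

Measured so far:
Compound 1, `Cc1ccc(OCC(=O)NNC(=O)c2cc3ccccc3oc2=O)c(C(=O)c2cccc(Cl)c2)c1`: 67300 nM
Compound 2, `Cc1ccc(OCC(=O)NNC(=O)c2cc3ccccc3oc2=O)c(C(=O)c2ccc(F)cc2)c1`: 43400 nM

In a functional assay on Ehrlich cells (Mus musculus) for cytotoxicity, read by trypan blue exclusion, with a stated time of 48 h (on this read-out higher numbers stand for weaker inhibition and lower numbers for stronger inhibition), compound 2 gives 43400 nM. Among the compounds with values here, its only measured neighbour is compound 1, and the two sit within the scatter of each other, as the step of a 1.6-fold lower number from compound 1 to compound 2 (0.19 log units; within the scatter) shows. Compound 3, `Cc1ccc(C(=O)c2cc(C)ccc2OCC(=O)NNC(=O)c2cc3ccccc3oc2=O)cc1`, differs from compound 2 by methyl in place of fluoro on an aromatic carbon. Within the data shown here, the one measured step that also swaps the group on this carbonyl-bearing ring, from compound 1 to compound 2, stayed within the scatter, so a change of similar size is expected here: a 1.0-fold higher number from compound 2 to compound 3 (0.02 log units; within the scatter). Compound 3 is therefore estimated at 45000 nM, with a range from 20000 nM to 100000 nM.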

Compound 3, half-maximal inhibitory concentration: 82600 nM
Compound 3: the middle estimate sits 1.8-fold (0.26 log units) below what was measured, and the stated range covers the measured number.
By their numbers in this assay, from the lowest: compounds 2, 1 and 3 (each within the scatter of the next).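

Methyl in place of fluoro on this aromatic carbon, para to a large group, gives a 1.9-fold higher number from compound 2 to compound 3 (0.28 log units; within the scatter) in this assay and 4-methylphenyl in place of 3-chlorophenyl on the carbonyl carbon gives a 1.2-fold higher number from compound 1 to compound 3 (0.09 log units; within the scatter). Neither step leaves the scatter, so a third group on this ring still yields no difference that can be told from repeat-measurement noise. No supporting data are available to explain these numbers. As far as these compounds go, whether an amine or a carboxylic acid in this place would give a step beyond the scatter remains open.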